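The compounds below may be only part of what the source reports. "The series", "measured", "known", "first", "only" and "open" are said of these compounds alone.

Measured compounds:
Compound 1 `c1cc(-c2ccn[nH]2)c2c(c1)C(c1ncc[nH]1)CC2` – 83%
Compound 2 `Cc1oncc1-c1cccc2c1CCC2c1ncc[nH]1` – 63%

In a functional assay on CHO cells for agonist activity at Alpha-1A adrenergic receptor (Homo sapiens), read by FLIPR and calcium flux (on this read-out higher numbers stand for larger maximal responses and lower numbers for smaller maximal responses), compound 1 gives 83% and compound 2 gives 63%. Compound 2 stands lowest of the two numbers; its nearest neighbour is compound 1, and the step of a number 20 percentage points lower from compound 1 to compound 2 (beyond the scatter) lies beyond the scatter. Compound 3 `Cn1cc(-c2cccc3c2CCC3c2ncc[nH]2)cn1` carries 1-methyl-1H-pyrazol-4-yl in place of 5-methyl-1,2-oxazol-4-yl on an aromatic carbon. Within the data shown here, the only measured step at this place, a number 20 percentage points lower from compound 1 to compound 2 (beyond the scatter), is an exchange of one five-membered aromatic ring for another, so it bears on the present change in kind, though not in the exact rings involved. With 5-methyl-1,2-oxazol-4-yl leaving and 1-methyl-1H-pyrazol-4-yl entering, a partial return toward the value of compound 1 is expected, though less than the full step. Compound 3 is therefore estimated at 72%, within 55% to 90%, which means an expected step of a number 9 percentage points higher from compound 2 to compound 3 (within the scatter).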

Compound 3, largest response reached (Emax), in percent of the reference or control that the assay uses: 12%
For compound 3 the middle estimate is 60 percentage points above the measured one; measured number outside the range, below it.
By their numbers in this assay, from the lowest: compound 3; then compound 2; then compound 1.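

In this assay the exchange of 5-methyl-1,2-oxazol-4-yl for 1-methyl-1H-pyrazol-4-yl gives a number 51 percentage points lower from compound 2 to compound 3 (beyond the scatter) although the heavy-atom, donor and acceptor counts stay the same, so this aromatic carbon responds strongly to a change those counts do not register. Replacing 1H-pyrazol-5-yl with 1-methyl-1H-pyrazol-4-yl gives a number 71 percentage points lower from compound 1 to compound 3 (beyond the scatter) and shows that two pyrazole groups can sit at opposite ends of the three numbers, so the ring type alone does not set the maximal response here. No evidence on hand gives a reason for these steps.

Compound 1 and compound 3 differ in both the ring attachment and the methyl group, and 1H-pyrazol-4-yl would be needed to separate the two. On these data alone, how a non-aromatic group, such as an aminomethyl or a carboxylic acid, would behave on this carbon also remains open.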